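Trifluoromethyl on the Phenyl Arm: From Compound 2 to Compound 3

The compounds below may be only part of what the source reports. "The series", "measured", "known", "first", "only" and "open" are said of these compounds alone.

Compound 1 `O=C(/C=C\Nc1ccc2cc[nH]c2c1)c1nc(-c2ccc(C(F)(F)F)cc2)n2ccccc12`: > 30000 nM
Compound 2 `COc1ccc(N/C=C\C(=O)c2nc(-c3ccccc3)n3ccccc23)cc1`: 7010 nM

Among the measured compounds shown here, in a functional assay on HCT-116 cells (Homo sapiens) for cytotoxicity, read by MTT assay, with a stated time of 48 h (on this read-out higher numbers stand for weaker inhibition and lower numbers for stronger inhibition), compound 2 gives 7010 nM, the only number in this set. Compound 1 reaches only a limit, > 30000 nM. Compound 3 `COc1ccc(N/C=C\C(=O)c2nc(-c3ccc(C(F)(F)F)cc3)n3ccccc23)cc1` differs from compound 2 by trifluoromethyl in place of hydrogen on an aromatic carbon. For the measured compounds named here, no measured pair covers this change. Because compound 1, which also bears the trifluoromethyl group, sits at the limit of > 30000 nM in this assay, at which 1 of the 2 values shown sits, compound 3 is expected to be somewhat weaker than compound 2, a step of a 1.7-fold higher number from compound 2 to compound 3 (0.23 log units; within the scatter) that may or may not pass beyond the scatter. Compound 3 is estimated at 12000 nM, in the range from 4000 nM to 40000 nM.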

Compound 3, half-maximal inhibitory concentration: 7720 nM
Beside the measured number, compound 3's estimate is 1.6-fold (0.19 log units) above it; low and high end bracket the measured number.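

In this assay, trifluoromethyl in place of hydrogen on the phenyl arm gives a 1.1-fold higher number from compound 2 to compound 3 (0.04 log units; within the scatter), so with 4-methoxyphenyl on the amine nitrogen this position accepts the group without a change beyond the scatter. With trifluoromethyl held in place, 4-methoxyphenyl in place of 1H-indol-6-yl on the amine nitrogen gives an at least 3.8-fold lower number from compound 1 to compound 3 (0.58 log units; beyond the scatter). Compound 1 stands at a limit, not a number: the limit of > 30000 nM in this assay, at which 1 of the 3 values shown sits.

On these data alone, how the phenyl arm behaves with 1H-indol-6-yl on the amine nitrogen stays open. So does whether a smaller group such as fluorine, or a carboxylic acid or an amine, would fare the same at this position.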